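From Fluorophenyl to Bromophenyl: A Cytotoxicity Forecast

The source may report more compounds than this note shows. Statements on the series, on what has been measured and on what is new or still open speak of the compounds shown alone.

Three close analogues share one core and differ only in the phenyl carried by the nitrogen on the aromatic ring. Compound 1 `COc1ccc(-n2nnnc2Nc2cccc(Cl)c2)cc1` gives 141000 nM in an ADME assay on HaCaT cells (Homo sapiens) for cytotoxicity, read by MTT assay, with a stated time of 72 h; on this read-out lower numbers stand for stronger inhibition and higher numbers for weaker inhibition. Compound 2 `COc1ccc(-n2nnnc2Nc2cccc(F)c2)cc1` gives 127000 nM in this assay, and compound 3 `COc1ccc(-n2nnnc2Nc2ccccc2F)cc1` gives 111000 nM there. Compound 3 sits at the lower edge of the three numbers, but the gaps are small: a 1.1-fold lower number from compound 2 to compound 3 (0.06 log units; within the scatter) and a 1.3-fold lower number from compound 1 to compound 3 (0.10 log units; within the scatter). Compound 4 `COc1ccc(-n2nnnc2Nc2cccc(Br)c2)cc1` has not yet been measured; the change is 3-bromophenyl in place of 2-fluorophenyl on a nitrogen on an aromatic ring. For the measured compounds named here, two measured steps bear on it. Fluoro in place of chloro gave a 1.1-fold lower number from compound 1 to compound 2 (0.05 log units; within the scatter), and 2-fluorophenyl in place of 3-chlorophenyl gave a 1.3-fold lower number from compound 1 to compound 3 (0.10 log units; within the scatter); neither the identity of the halogen nor the choice of phenyl moved the number beyond the scatter. The untested piece is bromine in place of chlorine within 3-bromophenyl, for which compound 1 is the nearest guide. Compound 4 is therefore estimated to give 135000 nM, within 70000 nM to 260000 nM. The expected step is a 1.2-fold higher number from compound 3 to compound 4 (0.09 log units; within the scatter), essentially none beyond the scatter.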

Compound 4, half-maximal inhibitory concentration: 138000 nM
Compound 4: the middle estimate sits 1.0-fold (0.01 log units) below what was measured, and the stated range covers the measured number.
By their numbers in this assay, from the lowest: compounds 3, 2, 4 and 1 (each within the scatter of the next).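

Bromo on an aromatic carbon of this phenyl behaves in this assay as chloro and fluoro do: bromo in place of chloro gives a 1.0-fold lower number from compound 1 to compound 4 (0.01 log units; within the scatter) and bromo in place of fluoro gives a 1.1-fold higher number from compound 2 to compound 4 (0.04 log units; within the scatter) as well. The change that alters both the halogen and its place, 3-bromophenyl in place of 2-fluorophenyl on a nitrogen on an aromatic ring, gives a 1.2-fold higher number from compound 3 to compound 4 (0.09 log units; within the scatter) and so, among these four compounds, no halogen and no phenyl sets one number apart from another. Nothing available explains why the numbers stay this close.

Going by these compounds, all four compounds carry a single halogen on this phenyl, so it remains open whether an amine or a carboxylic acid there would move the number beyond the scatter. On these data alone, whether a change elsewhere on the shared core would do so also remains open.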